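Hydroxymethyl to Methoxy on a Saturated Ring Carbon

This account rests on a few compounds, and the source may have more. Where it says the series, first, only, none or still open, it means among the compounds named here.

Of the compounds shown here, two sharing one core have been measured in an ADME assay on microsomes from liver (Mus musculus) for metabolic stability, read by LC-MS, using NADPH, with a stated time of 10 min, tested at 10 uM; a lower number here means that the compound disappears faster, a higher number that the compound lasts longer. Compound 1, `Nc1ncnc2c1c(Oc1cc(C(F)(F)F)ccn1)nn2[C@H]1CC[C@H](CO)CC1`, gives 0.383 h, and compound 2, `Nc1ncnc2c1c(Oc1cc(Cl)ccn1)nn2C1CCC1`, gives 0.0617 h. Compound 1 thus stands highest of the two numbers, and its gap to compound 2 lies beyond the usual scatter; the two differ in more than one place, so only the two values themselves can be compared. Compound 3, `CO[C@H]1CC[C@H](n2nc(Oc3cc(C(F)(F)F)ccn3)c3c(N)ncnc32)CC1`, has not yet been measured in this assay. It differs from compound 1 as follows: methoxy in place of hydroxymethyl on a saturated ring carbon. Going by the values given here, no measured pair shows this change, so its effect is unknown. The step from compound 1 to compound 3 in this assay is estimated to be small, a 1.3-fold lower number from compound 1 to compound 3 (0.11 log units; within the scatter), close to or within the scatter, leaning toward a lower number. Compound 3 is expected to give about 0.3 h, in a range from 0.1 h to 0.9 h.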

Compound 3, half-life: 0.217 h
Compound 3: middle estimate off by 1.4-fold (0.14 log units), on the high side; the range from low to high includes it.
By their numbers in this assay, from the lowest: compound 2; then compounds 3 and 1 (each within the scatter of the next).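

Going by these compounds alone, this pair is the first that differs in one place only, so the change from 4-(hydroxymethyl)cyclohexyl to 4-methoxycyclohexyl can be read directly in this assay, where it gives a 1.8-fold lower number from compound 1 to compound 3 (0.25 log units; within the scatter) on this saturated ring carbon. The two groups hold the same number of heavy atoms and differ in their count of hydrogen-bond donors, and in this one pair, that exchange leaves the two half-lives within the usual scatter of each other. Nothing measured here explains the result.

The compounds shown do not tell how an amine, a carboxylic acid or a longer ether chain would fare at this place in this assay. They also leave open whether the same exchange would read alike on a different pyridine substituent.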